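A few compounds are considered here, and "the series" means these few. Any claim that something is new, unique, unknown or untested is made for them only; others in the source may bear on it.

Measured in a functional assay on the whole organism for positive allosteric modulation, with Mus musculus as the target; on this read-out higher numbers stand for an effect only at larger amounts of compound and lower numbers for an effect already at smaller amounts:
- compound 1 `CCC(=O)N(c1ccccc1C)C1CCCC1N(C)C`: 7 mg/kg
- compound 2 `CCC(=O)N(c1cccc(F)c1)C1CCCC1N(C)C`: 0.4 mg/kg
- compound 3 `CCC(=O)N(c1ccc(Cl)c(Cl)c1)C1CCCC1N`: 0.02 mg/kg

Among these three, compound 3 has the lowest number, so its effect appears at the smallest amount of compound. Its gaps to compound 2 and compound 1 both lie beyond the scatter. These three compounds do not form a clean series, since no two of them differ in one place alone. Their values therefore give no direct measure of any single structural change.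

The next compound, compound 4 `CCC(=O)N(c1ccc(Cl)c(Cl)c1)C1CCCC1N(C)CCCN(C)C`, keeps the rest of compound 3 but carries (3-(dimethylamino)propyl)(methyl)amino in place of amino on a saturated ring carbon. Going by the values given here, the data hold no example of a group of this size at that place, so the expectation is uncertain. Among the compounds with values here, with compound 3 at 0.02 mg/kg, the lowest number so far, a change this large is expected to move the read-out upward rather than further down. The expected change in this assay is a 40-fold higher number from compound 3 to compound 4 (1.60 log units; beyond the scatter), which would lie beyond the scatter. For compound 4 the estimated value is 0.8 mg/kg, with an expected range from 0.06 mg/kg to 10 mg/kg.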

Compound 4, dose for half-maximal effect: 4 mg/kg
Compound 4: the middle estimate sits 5.0-fold (0.70 log units) below what was measured, within the range that was stated.
By their numbers in this assay, from the lowest: compound 3; then compound 2; then compounds 4 and 1 (each within the scatter of the next).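

In this assay, putting (3-(dimethylamino)propyl)(methyl)amino in place of amino on a saturated ring carbon gives a 200-fold higher number from compound 3 to compound 4 (2.30 log units; beyond the scatter). Going by these compounds alone, this is the first step in the set that changes one place alone, and it shows that the read-out depends strongly on what this ring carbon carries, with the larger group needing a much greater dose. The step exchanges a group of 1 heavy atom and 1 hydrogen-bond donor for one of 8 heavy atoms and 0 hydrogen-bond donors, and the data offer no measured explanation of why the read-out moves this far.

With size, chain length, the second nitrogen and the loss of the donor all changing together, this single step cannot show which of them matters. It leaves open where methylamino or dimethylamino on the core of compound 3 would fall between the two values, and whether a plain propyl chain on the same nitrogen, without the terminal dimethylamino, would behave like the full group in compound 4.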